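A few compounds are considered here, and "the series" means these few. Any claim that something is new, unique, unknown or untested is made for them only; others in the source may bear on it.

Compound 2 `COc1ccccc1C(=O)Nc1cccc(NC(=O)C(C)C)c1` sits at a limit of an in vitro functional assay on HEK293-A cells for antagonist activity at metabotropic glutamate receptor 5 (Rattus norvegicus), read by calcium flux; a lower number here means a stronger inhibitor, a higher number a weaker inhibitor: in this assay compound 2 gives > 30000 nM, which is a limit rather than a number. Compound 1 `COc1ccccc1C(=O)Nc1cccc(NC(=O)c2ccc(Cl)c(Cl)c2)c1` is also at a limit, giving > 30000 nM in this assay. The step that the two limits leave unreadable from compound 1 to compound 2 cannot be read, since (the limit of > 30000 nM in this assay, at which 2 of the 2 values shown sit). Compound 3 `COCC(=O)Nc1cccc(NC(=O)c2ccccc2OC)c1` differs from compound 2 by methoxymethyl in place of isopropyl on a carbonyl carbon. Among the measured compounds shown here, no measured step speaks to this change, so the expected step that the limit leaves unreadable from compound 2 to compound 3 is a guess anchored to the limit. Compound 3 is therefore estimated at 40000 nM, with a range of 15000 nM to 150000 nM, most likely again reported as a limit.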

Compound 3, half-maximal inhibitory concentration: > 30000 nM
Compound 3: a limit, no number (the forecaster's own chance of this, stated with the estimate: 85%); the middle value is on the limit's open side.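

No step among compound 1, compound 2 and compound 3 can be read, since each stands at a limit rather than a number: the limit of > 30000 nM in this assay, at which 3 of the 3 values shown sit.

The compounds shown leave open which change to the shared core, if any, would give a measurable value in this assay.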